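Chain length and alpha-branching at the acid end of the series

The compounds below may be only part of what the source reports. "The series", "measured", "known", "first", "only" and "open" are said of these compounds alone.

Among the compounds with values here, the series shares one core carrying a side chain that ends in a carboxylic acid; the three measured members are compound 1 `O=C(O)CCCCOc1cc(-c2ccccc2)cc(-c2ccccc2)n1`, compound 2 `O=C(O)CCCCCOc1cc(-c2ccccc2)cc(-c2ccccc2)n1` and compound 3 `CC(CCCCOc1cc(-c2ccccc2)cc(-c2ccccc2)n1)C(=O)O`. In an assay on cell membranes from spleen (Cavia porcellus) for binding affinity to leukotriene B4 receptor 1 (Homo sapiens) (a higher number here means a weaker inhibitor, a lower number a stronger inhibitor), compound 1 gives 50 nM, compound 2 gives 3 nM and compound 3 gives 4 nM. Lengthening the chain by one carbon moves the number strongly, a 17-fold lower number from compound 1 to compound 2 (1.22 log units; beyond the scatter); the branched homologue shows a similar gain, a 13-fold lower number from compound 1 to compound 3 (1.10 log units; beyond the scatter); the added methyl on its own makes no clear difference, a 1.3-fold higher number from compound 2 to compound 3 (0.12 log units; within the scatter). Compound 3 thus stands close to compound 2, both far from compound 1.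

Compound 4 `CC(C)(CCCCCCOc1cc(-c2ccccc2)cc(-c2ccccc2)n1)C(=O)O` differs from compound 3 as follows: 3-carboxy-3-methylbutyl in place of 1-carboxyethyl on a saturated chain carbon, four bonds along the chain from an oxygen on an aromatic ring. The acid end moves two carbons further out and gains a second methyl on the carbon bound to the carbonyl. The chain-length steps bear on this, and they were large but point only from a shorter to the present length; the methyl step was within the scatter. Further lengthening is untested, so the outcome is uncertain. Compound 4 is expected to stay near compound 3, with a step of a 1.5-fold higher number from compound 3 to compound 4 (0.18 log units; within the scatter) in this assay; its estimated value is 6 nM, within a range from 1.5 nM to 25 nM.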

Compound 4, half-maximal inhibitory concentration: 22 nM
Compound 4: middle estimate off by 3.7-fold (0.56 log units), on the low side; measured number inside the range.
By their numbers in this assay, from the lowest: compounds 2 and 3 (each within the scatter of the next); then compound 4; then compound 1.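

In this assay, moving the acid further out no longer helps: 3-carboxy-3-methylbutyl in place of 1-carboxyethyl gives a modest loss (a 5.5-fold higher number from compound 3 to compound 4 (0.74 log units; beyond the scatter)), and the comparison with the unbranched acid is also modest (a 7.3-fold higher number from compound 2 to compound 4 (0.87 log units; beyond the scatter)). Part of the gain over the shortest acid survives (a 2.3-fold lower number from compound 1 to compound 4 (0.36 log units; beyond the scatter)), so across compounds 1, 3 and 4 the number first falls and then rises as the group at this position grows. No measurement at hand accounts for that rise.

The longer chain and the second methyl enter together, so their shares in the loss cannot be separated. On these data alone, a single methyl on the longer chain, or two methyl groups on the chain of compound 3, would separate them, and a still longer chain remains open.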